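A Hydroxypropyl Swap on a Weak Myosin Inhibitor

The source may hold more compounds than are shown below. What is called first, only, known or untested is meant among the compounds shown, and "the series" means these compounds.

Three close relatives have been tested in an assay on isolated protein for inhibition of myosin-2 (Bos taurus), read by spectrophotometry, with a stated time of 24 min; a higher number here means a weaker inhibitor, a lower number a stronger inhibitor. Compound 1 `C/C(=N\CC1CCCCC1)c1c(O)c2ccccc2[nH]c1=O` gives >= 100000 nM, which is a limit of the assay rather than a number. Compound 3 `C/C(=N\OCc1ccccc1)c1c(O)c2ccccc2oc1=O` likewise gives >= 100000 nM, again only a limit. Compound 2 `CCC(C)/N=C(\C)c1c(O)c2ccccc2oc1=O` gives >= 100000 nM, also a limit and not a number, so compound 2 stands exactly where every other value stands: the limit of >= 100000 nM in this assay, at which 3 of the 3 values shown sit. Going by the values given here, no step between measured compounds can be sized from these data. Compound 4 `C/C(=N\CCCO)c1c(O)c2ccccc2oc1=O` differs from compound 2 by 3-hydroxypropyl in place of sec-butyl on a double-bonded nitrogen. With every known value sitting at the limit, no shift beyond the scatter is expected in this assay, in either direction. Compound 4 is therefore expected to give 100000 nM (range 30000 nM to 300000 nM), an expected step of a number no higher from compound 2 to compound 4 (the limit leaves the size open).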

Compound 4, half-maximal inhibitory concentration: 37000 nM
Compound 4: the middle estimate sits 2.7-fold (0.43 log units) above what was measured, within the range that was stated.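

Putting 3-hydroxypropyl in place of sec-butyl on the double-bonded nitrogen gives an at least 2.7-fold lower number from compound 2 to compound 4 (0.43 log units; beyond the scatter), the first sign that this position can shift the read-out in this assay. The value of compound 2 is a limit and not a number, which leaves the full size of this step open. Compound 4 is the only compound shown with a true number, as the others remain at a ceiling: the limit of >= 100000 nM in this assay, at which 3 of the 4 values shown sit.

As far as these compounds go, whether the gain comes from the hydroxyl or from the chain itself stays open. An amine, a carboxylic acid or a longer chain at this position would help to separate the two.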